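The source may hold more compounds than are shown below. What is called first, only, known or untested is meant among the compounds shown, and "the series" means these compounds.

In an ADME assay on GES1 cells (Homo sapiens) for inhibition, read by MTT assay, with a stated time of 72 h (on this read-out higher numbers stand for weaker inhibition and lower numbers for stronger inhibition), compound 1 `Cc1cc(Nc2ccn(Cc3cccc4ccccc34)n2)n2nc(SCc3ccc(Br)cc3)nc2n1` gives 30000 nM. Compound 2 `Cc1cc(Nc2cc(-c3ccccc3)[nH]n2)n2nc(SCc3csc4ccccc34)nc2n1` gives 29200 nM in this assay, the lowest of the two numbers shown, though its gap to compound 1 lies within the scatter, so no order between the two is claimed. Compound 3 `CCCCCc1c(C)nc2nc(SCc3ccc(Cl)cc3)nn2c1Nc1cc(-c2ccccc2)[nH]n1` returns only a limit of this assay, > 50000 nM, as noted in the limit of > 50000 nM in this assay, at which 1 of the 3 values shown sits. Compound 4 `Cc1cc(Nc2cc(-c3ccccc3)[nH]n2)n2nc(SCCc3ccccc3)nc2n1` is not yet measured in this assay. Compared with compound 2 it carries benzyl in place of 1-benzothiophen-3-yl on a saturated chain carbon bound to a sulfur. No measured pair in this assay differs in a single place, so no step size is known from the data; with the two numbers shown so close and one value at the limit, no step beyond the scatter is expected in either direction. Compound 4 is expected near 30000 nM in this assay, within 12000 nM to 50000 nM. This amounts to an expected step of a 1.0-fold higher number from compound 2 to compound 4 (0.01 log units; within the scatter).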

Compound 4, half-maximal inhibitory concentration: 37400 nM
For compound 4 the middle estimate is 1.2-fold (0.10 log units) below the measured one, within the range that was stated.
By their numbers in this assay, from the lowest: compounds 2, 1 and 4 (each within the scatter of the next). At a limit, above all of these: compound 3.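

In this assay, the only single-place pair shown gives a 1.3-fold higher number from compound 2 to compound 4 (0.11 log units; within the scatter), so benzyl in place of 1-benzothiophen-3-yl on a saturated chain carbon bound to a sulfur produces no readable change. Within the data shown here, this is the first direct reading at this position, and the loss of the five-membered aromatic ring leaves the number within the scatter.

How far numbers in this series can rise remains only partly readable: the limit of > 50000 nM in this assay, at which 1 of the 4 values shown sits.
On these data alone, whether an amine, a carboxylic acid or a longer chain at this place would give a step beyond the scatter remains open.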